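Cyclobutyl Carboxamide in Place of the Hydroxycyclohexyl Group

The source may report more compounds than this note shows. Statements on the series, on what has been measured and on what is new or still open speak of the compounds shown alone.

Compound 1 `N#Cc1cnc(NCc2cnccc2C(F)(F)F)cc1N[C@H]1CC[C@H](O)CC1` stands weakest of the three measured compounds in an assay on isolated protein for inhibition of protein kinase C theta type (Homo sapiens), read by TR-FRET, with a stated time of 2 h (on this read-out higher numbers stand for weaker inhibition and lower numbers for stronger inhibition), where compound 1 gives 350 nM. Its nearest neighbour in this assay is compound 3 `CC1(C)[C@@H](Nc2nc(NCc3cnccc3C(F)(F)F)ncc2C#N)C[C@@H]1O`, which gives 170 nM, and farthest away stands compound 2 `CC1(C)[C@@H](O)C[C@H]1Nc1nc(NCc2cnccc2C(F)(F)F)ncc1C#N`, which gives 4 nM. Compounds 2 and 3 share a core that differs from that of compound 1, and between themselves they have the same atoms and bonds; their only difference is configuration as drawn, yet that alone gives a 43-fold higher number from compound 2 to compound 3 (1.63 log units; beyond the scatter) in this assay, a reading that rests on (the fact that compounds 2 and 3 differ only in the configuration as drawn). The unmeasured compound 4 `CC1(C)[C@H](Nc2cc(NCc3cnccc3C(F)(F)F)ncc2C#N)C[C@H]1C(N)=O` keeps the core of compound 1 and changes the group on the aromatic nitrogen: 3-carbamoyl-2,2-dimethylcyclobutyl in place of 4-hydroxycyclohexyl on a nitrogen on an aromatic ring. Within the data shown here, no measured pair tracks this exact exchange on the core of compound 1. Among the measured compounds shown here, the only guidance is that, on their different core, both compound 2 and compound 3, each carrying a 2,2-dimethylcyclobutyl group on that nitrogen, give lower numbers than compound 1, while the configuration of that small ring decides how much lower. Compound 4 is therefore expected to give a lower number, an 8.8-fold lower number from compound 1 to compound 4 (0.94 log units; beyond the scatter), with an estimate of 40 nM and a range from 6 nM to 300 nM.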

Compound 4, half-maximal inhibitory concentration: 140 nM
For compound 4 the middle estimate is 3.5-fold (0.54 log units) below the measured one; the range from low to high includes it.
By their numbers in this assay, from the lowest: compound 2; then compounds 4 and 3 (each within the scatter of the next); then compound 1.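

Among these compounds, on the core of compound 1, this is the first reading of an exchange at the group on the aromatic nitrogen. In this assay, 3-carbamoyl-2,2-dimethylcyclobutyl in place of 4-hydroxycyclohexyl gives a 2.5-fold lower number from compound 1 to compound 4 (0.40 log units; beyond the scatter), so this position accepts a four-membered ring bearing a carboxamide instead of a six-membered ring bearing a hydroxyl, and the number still falls modestly. Until now the 2,2-dimethylcyclobutyl group had been seen only on the different core of compound 2 and compound 3, and nothing shown here accounts for the size of this step.

The exchange alters the ring, the dimethyl pair and the carboxamide together, so the compounds shown leave open which of these carries the step, and whether a hydroxyl, an amine or a carboxylic acid on the same small ring would read differently on this core. They also leave open whether the configuration of the small ring matters as much on the core of compound 1 as on the other core, where it gives a 43-fold higher number from compound 2 to compound 3 (1.63 log units; beyond the scatter).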